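This account rests on a few compounds, and the source may have more. Where it says the series, first, only, none or still open, it means among the compounds named here.

Compound 3 `O=c1ccoc2cc(OCc3cn(Cc4cccc([N+](=O)[O-])c4)nn3)ccc12` stands at the limit of the assay: in a functional assay on MDA-MB-231 cells (Homo sapiens) for cytotoxicity, read by MTT assay, with a stated time of 48 h (on this read-out higher numbers stand for weaker inhibition and lower numbers for stronger inhibition), compound 3 gives only a limit, > 100000 nM, and no number. Compound 2 `O=c1ccoc2cc(OCc3cn(Cc4cccc(Br)c4)nn3)ccc12` likewise yields only a limit, > 100000 nM. For the measured compounds named here, the single measured number belongs to compound 1 `Cc1cccc(Cn2cc(COc3ccc4c(=O)ccoc4c3)nn2)c1`, which in this assay gives 16000 nM. The line the limit of > 100000 nM in this assay, at which 2 of the 3 values shown sit, marks where compound 2 and compound 3 rest. Compound 4 `O=c1ccoc2cc(OCc3cn(Cc4ccc(Br)cc4)nn3)ccc12` differs from compound 3 by 4-bromophenyl in place of 3-nitrophenyl on a saturated chain carbon bound to an aromatic nitrogen. Going by the values given here, two measured steps bear on this change, an at least 6.2-fold higher number from compound 1 to compound 2 (0.79 log units; beyond the scatter) and an at least 6.2-fold higher number from compound 1 to compound 3 (0.79 log units; beyond the scatter), while the step that the two limits leave unreadable from compound 2 to compound 3 cannot be sized. Both departures from methyl drove the value to the limit, and compound 4, like compound 2, carries a bromine on its ring, so the step of an at least 1.1-fold lower number from compound 3 to compound 4 (0.04 log units; that floor lies within the scatter) is expected to remain within the scatter, most probably ending again at a limit. Compound 4 is therefore estimated at 90000 nM, with a range from 30000 nM to 300000 nM.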

Compound 4, half-maximal inhibitory concentration: > 100000 nM
Compound 4 gave a limit, no number; the forecaster's own chance of this, stated with the estimate: 70%; middle value at least 1.1-fold (0.04 log units) from the limit.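

In this assay the change from 3-methylphenyl to 4-bromophenyl on a saturated chain carbon bound to an aromatic nitrogen gives an at least 6.2-fold higher number from compound 1 to compound 4 (0.79 log units; beyond the scatter). The value of compound 4 is a limit and not a number, so the 4-bromophenyl group, like the 3-bromophenyl group of compound 2, gives no measurable value here. The steps joining compound 4 to compound 2 and compound 3 cannot be read, because all three compounds rest at one shared line: the limit of > 100000 nM in this assay, at which 3 of the 4 values shown sit.

From the compounds shown here alone, only the 3-methylphenyl group of compound 1 gives a number, so it remains open whether a 4-methylphenyl, 3-ethylphenyl or 3-methoxyphenyl group would also give one. Going by these compounds, how far compound 2, compound 3 and compound 4 differ from one another also remains open.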